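This account rests on a few compounds, and the source may have more. Where it says the series, first, only, none or still open, it means among the compounds named here.

For the measured compounds named here, in an assay on HEK293 cells for displacement of a labelled ligand from growth hormone secretagogue receptor type 1 (Homo sapiens), with a stated time of 60 min (on this read-out lower numbers stand for stronger inhibition and higher numbers for weaker inhibition), compound 3 `CCN(CC)CCCS(=O)(=O)c1ccc2nc(NC(=O)NC(=O)c3ccccc3Cl)sc2c1` gives 13 nM, the highest of the three numbers measured so far. Compound 1 `CN1CCCN(CCCS(=O)(=O)c2ccc3nc(NC(=O)NC(=O)c4ccccc4Cl)sc3c2)CC1` gives 4.2 nM, and compound 2 `COCCNCCCS(=O)(=O)c1ccc2nc(NC(=O)NC(=O)c3ccccc3Cl)sc2c1` gives 8.6 nM. Compound 4 `CN(C)CCCS(=O)(=O)c1ccc2nc(NC(=O)NC(=O)c3ccccc3Cl)sc2c1` has not yet been measured; it differs from compound 3 in one place: dimethylamino in place of diethylamino on a saturated chain carbon, three bonds along the chain from a sulfonyl sulfur.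

Every measured step here alters the same amine at the end of the chain, so all three bear on this change to some degree. Replacing the ring amine of compound 1 with an open-chain amine raised the number in both cases, as seen in a 3.1-fold higher number from compound 1 to compound 3 (0.49 log units; beyond the scatter) and a 2.0-fold higher number from compound 1 to compound 2 (0.31 log units; beyond the scatter). Exchanging one open-chain amine for another, however, made little difference: a 1.5-fold higher number from compound 2 to compound 3 (0.18 log units; within the scatter) stays within the scatter. Going by the values given here, the move from diethylamino to dimethylamino is a trimming of this kind, not a return to a ring, so the closest precedent suggests a small shift at most.

The expectation for compound 4 is therefore a number close to that of compound 3, with a 1.2-fold lower number from compound 3 to compound 4 (0.07 log units; within the scatter) most likely falling within the scatter; compound 4 is estimated at 11 nM, with a range from 4.5 nM to 27 nM.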

Compound 4, half-maximal inhibitory concentration: 8.7 nM
For compound 4 the middle estimate is 1.3-fold (0.10 log units) above the measured one; measured number inside the range.
By their numbers in this assay, from the lowest: compound 1; then compounds 2, 4 and 3 (each within the scatter of the next).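

Trimming diethylamino to dimethylamino on the saturated chain carbon, three bonds along the chain from the sulfonyl sulfur, gives a 1.5-fold lower number from compound 3 to compound 4 (0.17 log units; within the scatter), and exchanging (2-methoxyethyl)amino for dimethylamino gives a 1.0-fold higher number from compound 2 to compound 4 (0.01 log units; within the scatter), so all three open-chain amines now lie within the scatter of one another, whichever pair is compared. Against the ring amine, the new compound shows the same kind of gap as the other two, with a 2.1-fold higher number from compound 1 to compound 4 (0.32 log units; beyond the scatter), which leaves compound 1 as the only one whose number is lower than each of the others by more than the scatter. The compounds shown offer no measurement that explains either the similarity among the open-chain amines or the gap to compound 1.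

From the compounds shown here alone, with 4-methyl-1,4-diazepan-1-yl as the only ring amine here, it remains open whether a morpholine ring or a 4-methylpiperazine ring at the end of the chain would read like compound 1 or like the open-chain amines. Going by these compounds, it is also open how a primary amine at this position, or a longer chain carrying the same dimethylamino group, would read.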